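The compounds below may be only part of what the source reports. "The series", "measured", "known", "first", "only" and "open" are said of these compounds alone.

Values in a functional assay on MCF7 cells (Homo sapiens) for antiproliferative activity, read by sulforhodamine B assay, with a stated time of 48 h (on this read-out higher numbers stand for weaker inhibition and lower numbers for stronger inhibition), for the measured compounds
- compound 1 `Cc1ccc(NS(=O)(=O)c2ccc(N3CCNC3=O)cc2)cc1` gives 610 nM
- compound 2 `CCCCCCCc1ccc(NS(=O)(=O)c2ccc(N3CCNC3=O)cc2)cc1` gives > 1000 nM (a limit of the assay, not a number)
- compound 3 `O=C1NCCN1c1ccc(S(=O)(=O)Nc2ccc(Cl)cc2)cc1` gives 170 nM

Among the measured compounds shown here, compound 3 has the lower of the two actual numbers and is the most potent of the three in this assay so far. Chloro in place of methyl gave a 3.6-fold lower number from compound 1 to compound 3 (0.55 log units; beyond the scatter) in this series.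

The next compound is compound 4 `CCCCCCOc1ccc(NS(=O)(=O)c2ccc(N3CCNC3=O)cc2)cc1` with hexyloxy in place of chloro on an aromatic carbon of a six-membered aromatic ring of carbon only, para to a large group.

The closest guide is compound 2, which carries a heptyl chain where compound 4 carries hexyloxy. Chloro in place of heptyl gave an at least 5.8-fold lower number from compound 2 to compound 3 (0.76 log units; beyond the scatter) and the new change runs the opposite way, from chloro back to a long chain. The comparison of the heptyl and methyl compounds gave an at least 1.6-fold higher number from compound 1 to compound 2 (0.21 log units; that floor lies within the scatter) so it adds little. For the measured compounds named here, no hexyloxy compound has been measured, which leaves the size of the step uncertain.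

A clear rise is expected, with the estimated step being a 7.1-fold higher number from compound 3 to compound 4 (0.85 log units; beyond the scatter) and a real chance that the assay reports only a limit. For compound 4 the estimate is 1200 nM with an expected range from 400 nM to 5000 nM in this assay.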

Compound 4, half-maximal inhibitory concentration: > 1000 nM
Compound 4: only a limit was reported; the forecaster's own chance of this, stated with the estimate: 55%; the middle value lies beyond the limit too.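

Hexyloxy in place of chloro on this aromatic carbon, para to a large group, gives an at least 5.8-fold higher number from compound 3 to compound 4 (0.76 log units; beyond the scatter) in this assay, so the long oxygen-linked chain is clearly worse than chloro here. Against the methyl of compound 1, hexyloxy gives an at least 1.6-fold higher number from compound 1 to compound 4 (0.21 log units; that floor lies within the scatter), a floor too small to establish a loss on its own. Compound 2 and compound 4 now both end at a limit rather than a number, so a long chain with the oxygen and one without it both fall well short of chloro, yet the step between them cannot be read because they share that limit: the limit of > 1000 nM in this assay, at which 2 of the 4 values shown sit.

Going by these compounds, what remains open is how far compound 4 lies past its limit, and so whether hexyloxy is any different from the heptyl chain of compound 2. A methoxy group or an amine at this position would help show whether the oxygen link itself can be tolerated when the long chain is absent, and how short a chain must be to bring the number back towards that of compound 3.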